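The source may report more compounds than this note shows. Statements on the series, on what has been measured and on what is new or still open speak of the compounds shown alone.

Series notes. Compound 1 `Cc1ccc(-c2nnc(SCCCN3CCN(c4nc5ccccc5o4)CC3)o2)cc1` serves as the reference; in a functional assay on A-431 cells (Homo sapiens) for inhibition, read by MTT assay, with a stated time of 72 h (on this read-out higher numbers stand for weaker inhibition and lower numbers for stronger inhibition), compound 1 gives 100000 nM. Compound 2 `Clc1ccc(-c2nnc(SCCCN3CCN(c4nc5ccccc5o4)CC3)o2)cc1` carries chloro in place of methyl on an aromatic carbon and in this assay compound 2 gives 89600 nM, so that a 1.1-fold lower number from compound 1 to compound 2 (0.05 log units; within the scatter). Compound 3 `Cc1ccc(-c2nnc(SCCCN3CCN(c4nc5ccccc5s4)CC3)o2)cc1` differs from compound 1 by 1,3-benzothiazol-2-yl in place of 1,3-benzoxazol-2-yl on an amine nitrogen in a ring; in this assay compound 3 gives 61600 nM, and a 1.6-fold lower number from compound 1 to compound 3 (0.21 log units; within the scatter). Among the compounds with values here, all three numbers lie close together and no step among them stands apart from the scatter.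

Compound 4 `Clc1ccc(-c2nnc(SCCCN3CCN(c4nc5ccccc5s4)CC3)o2)cc1` is not yet measured. Relative to compound 3 it shows (chloro in place of methyl on an aromatic carbon), the same change already made from compound 1 to compound 2; among the compounds here this change occurs twice in all, and the two place descriptions match word for word. Within the data shown here, the step of a 1.1-fold lower number from compound 3 to compound 4 (0.05 log units; within the scatter) is expected in this assay, the sole precedent being a 1.1-fold lower number from compound 1 to compound 2 (0.05 log units; within the scatter), a step within the scatter. Compound 4 is therefore expected to give about 55000 nM in this assay. For compound 4 the expected range runs from 28000 nM to 100000 nM.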

Compound 4, half-maximal inhibitory concentration: 69200 nM
The estimate for compound 4 lay 1.3-fold (0.10 log units) below the measured number; measured number inside the range.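

In this assay, chloro in place of methyl gives a 1.1-fold higher number from compound 3 to compound 4 (0.05 log units; within the scatter), and this agrees with the same change on the core of compound 1: the same change on two cores in this assay, a 1.1-fold lower number (0.05 log units; within the scatter) from compound 1 to compound 2 and a 1.1-fold higher number (0.05 log units; within the scatter) from compound 3 to compound 4, 1.3-fold (0.10 log units) apart, within the scatter of two such steps. Likewise, 1,3-benzothiazol-2-yl in place of 1,3-benzoxazol-2-yl on an amine nitrogen in a ring gives a 1.3-fold lower number from compound 2 to compound 4 (0.11 log units; within the scatter), and this agrees with the earlier step: the same change on two cores in this assay, a 1.6-fold lower number (0.21 log units; within the scatter) from compound 1 to compound 3 and a 1.3-fold lower number (0.11 log units; within the scatter) from compound 2 to compound 4, 1.3-fold (0.10 log units) apart, within the scatter of two such steps. Both changes thus carry across the two cores shown without a detectable shift, but each step lies within the scatter and each change rests on one pair of steps, so this shows only that neither change moves the number measurably here, not that an effect of any particular size or direction transfers from core to core.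

Left open is whether a carboxylic acid or an amine in place of the methyl or chloro, or a longer chain joining the two ends of the molecule, would give a step beyond the scatter in this assay. Also open, on these data alone, is how these four compounds behave on any other cell line.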